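The source may report more compounds than this note shows. Statements on the series, on what has been measured and on what is new or still open speak of the compounds shown alone.

Measured so far in a functional assay on CHOK cells for antagonist activity at growth hormone secretagogue receptor type 1 (Homo sapiens), read by calcium flux; on this read-out lower numbers stand for stronger inhibition and higher numbers for weaker inhibition:
compound 1 `Nc1nc(N)c(-c2ccc(NCc3ccnc(Cl)c3)cc2)c(COCc2ccccc2)n1` gives 3.6 nM.
compound 2 `Nc1nc(N)c(-c2ccc(NCc3csc(Cl)c3)cc2)c(COCc2ccccc2)n1` gives 170 nM.
compound 3 `N#Cc1ccc(COc2ccc(-c3c(N)nc(N)nc3COCc3ccccc3)cc2)cc1` gives 3610 nM.

Compound 3 stands at the highest number of the three, weakest of the set, and both steps into it are large: a 1000-fold higher number from compound 1 to compound 3 (3.00 log units; beyond the scatter) and a 21-fold higher number from compound 2 to compound 3 (1.33 log units; beyond the scatter). The remaining step, a 47-fold higher number from compound 1 to compound 2 (1.67 log units; beyond the scatter), shows that the group carried on the nitrogen-linked side also moves the number strongly.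

Compound 4 `Nc1nc(N)c(-c2ccc(CNc3ccc([N+](=O)[O-])cc3)cc2)c(COCc2ccccc2)n1` is not yet measured. It differs from compound 3 in one place: ((4-nitrophenyl)amino)methyl in place of (4-cyanobenzyl)oxy on an aromatic carbon. The two steps that bear on this position both ran from an amino-linked group to the oxygen-linked cyanobenzyl and both rose sharply, so a return to a group with a hydrogen-bond donor at this position points toward a lower number. Within the data shown here, the linkage in compound 4 is inverted, the chain carbon now sitting on the core side and the nitrogen on the nitrophenyl ring, and a nitro group appears that no measured compound carries; no measured pair isolates either change, so the size is uncertain.

For compound 4 the expectation is a drop beyond the scatter but short of a full return to the level of compound 1 or compound 2: an estimated 700 nM, range 120 nM to 4000 nM, which means an expected step of a 5.2-fold lower number from compound 3 to compound 4 (0.71 log units; beyond the scatter).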

Compound 4, half-maximal inhibitory concentration: 16 nM
Estimate against measurement, compound 4: 44-fold (1.64 log units) above; the whole stated range lies above it.
By their numbers in this assay, from the lowest: compound 1; then compound 4; then compound 2; then compound 3.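

In this assay, the ((4-nitrophenyl)amino)methyl group recovers most of what the (4-cyanobenzyl)oxy group gives up, with a 230-fold lower number from compound 3 to compound 4 (2.35 log units; beyond the scatter), so a low number at this aromatic carbon does not depend on the nitrogen being the atom bound to it: a chain carbon can hold that place, and all three amino-linked groups now lie below the oxygen-linked one, with no compound shown going against this. The ring carried on the amino-linked chain still separates these compounds, since the nitrophenyl group gives an 11-fold lower number from compound 2 to compound 4 (1.03 log units; beyond the scatter) against the chlorothiophene group but a 4.4-fold higher number from compound 1 to compound 4 (0.65 log units; beyond the scatter) against the chloropyridine group. No supporting data accompany these results to explain any of the steps.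

On these data alone, the inverted linkage and the nitro group enter together, so their separate shares of the step remain open; a ((4-cyanophenyl)amino)methyl group and a (4-nitrobenzyl)amino group at this position would pull them apart. As far as these compounds go, whether the amino hydrogen itself matters also remains open, and an N-methyl amine in the same linker would address that.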